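A few compounds are considered here, and "the series" means these few. Any claim that something is new, unique, unknown or untested is made for them only; others in the source may bear on it.

Measured so far in a physicochemical assay for solubility, read by HPLC, in phosphate buffer, measured as kinetic solubility, with a stated time of 1 h, at pH 7.4, tested at 250 uM; a lower number here means a less soluble compound, a higher number a more soluble compound:
- compound 1 `CC(C)N1CCC(c2ccc3c(c2)oc(=O)n3C(=O)NCCCCc2ccccc2)CC1`: 50000 nM
- compound 2 `O=C(NCCCCc1ccccc1)n1c2c(oc1=O)CNCC2`: 230000 nM
- compound 3 `CN1CCC(c2ccc3c(c2)oc(=O)n3C(=O)NCCCCc2ccc(F)cc2)CC1`: 22000 nM

Compound 1 holds the second highest of the three numbers in this assay. Compound 2 lies higher and compound 3 lies lower, and both gaps to compound 1 are beyond the usual scatter.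

The next compound is compound 4 `CC(C)CN1CCC(c2ccc3c(c2)oc(=O)n3C(=O)NCCCCc2ccccc2)CC1`, still unmeasured. It differs from compound 1 in one place: isobutyl in place of isopropyl on an amine nitrogen in a ring. This puts isobutyl in place of isopropyl on an amine nitrogen in a ring, so 1-isopropylpiperidin-4-yl becomes 1-isobutylpiperidin-4-yl.

Going by the values given here, no pair of measured compounds differs in only one place, so the series offers no direct measure of how large this kind of step might be. The expectation therefore starts from the closest measured structure, compound 1 at 50000 nM, and allows a wide margin. The estimated step of a 1.4-fold lower number from compound 1 to compound 4 (0.15 log units; within the scatter) is a small one toward lower solubility, and it is not expected to go beyond the scatter. For compound 4 the estimated solubility is 35000 nM, with an expected range of 16000 nM to 75000 nM.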

Compound 4, solubility: < 1000 nM
Compound 4 ended at the assay's limit; the forecaster's own chance of this, stated with the estimate: 5%; at least 35-fold (1.54 log units) between middle value and limit.
By their numbers in this assay, from the lowest: compound 3; then compound 1; then compound 2. At a limit, below all of these: compound 4.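

In this assay, the amine nitrogen in the six-membered non-aromatic ring proves to be a place where a small change in the substituent can coincide with a large step: isobutyl, with 4 heavy atoms, in place of isopropyl, with 3 heavy atoms, gives an at least 50-fold lower number from compound 1 to compound 4 (1.69 log units; beyond the scatter). Going by these compounds alone, this is the first single-place step, as the earlier compounds differ from each other in more than one place and gave no measure of any step at this nitrogen. Compound 4 gives < 1000 nM, which is a limit of the assay and not a number, so the step gives only a bound on the true size of the change: the limit of < 1000 nM in this assay, at which 1 of the 4 values shown sits.

The compounds shown leave open whether this step is specific to isobutyl or extends to other groups on the same nitrogen, such as a longer chain like n-butyl, a cyclopropylmethyl group or a hydroxyethyl chain. They also leave open whether the same change would give a step of similar size with the 4-fluorophenyl end of compound 3 in place of the phenyl end of compound 1.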